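Inverting one stereocentre of compound 1

The compounds below may be only part of what the source reports. "The series", "measured", "known", "first", "only" and "open" are said of these compounds alone.

Measured in an ADME assay on MT4 cells (Homo sapiens) for cytotoxicity, read by MTT assay, with a stated time of 5 days; a higher number here means that more compound is tolerated, a lower number that less compound is tolerated:
Compound 1 (`Cc1c(N)nc(Nc2ccc(C#N)cc2)nc1[C@H](C)c1c(F)cccc1F`) (31000 nM)
Compound 2 (`CCCN(C)c1nc(C(C)c2c(F)cccc2F)c(C)c(=O)[nH]1`) (> 78000 nM)
Compound 3 (`CCCN(C)c1nc([C@H](C)c2c(F)cccc2F)c(C)c(=O)[nH]1`) (75000 nM)

Compound 2 (> 78000 nM) stands at a limit of the assay and not at a number. Compound 1 (31000 nM) and compound 3 (75000 nM) lie further apart than the usual scatter, with compound 1 the lower of the two.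

Compound 4 (`Cc1c(N)nc(Nc2ccc(C#N)cc2)nc1[C@@H](C)c1c(F)cccc1F`) differs from compound 1 only in configuration as drawn (the two compounds have the same atoms and bonds and differ only in configuration as drawn: 1 of 1 stereo elements differ; a stereocentre at a saturated chain carbon is drawn R in compound 1 and S in compound 4): a stereocentre at a saturated chain carbon is drawn R in compound 1 and S in compound 4. For the measured compounds named here, the only measured step that bears on this is a stereo one (an at least 1.0-fold lower number from compound 2 to compound 3 (0.01 log units; that floor lies within the scatter)), and it rests on a limit (the limit of > 78000 nM in this assay, at which 1 of the 3 values shown sits) and on a comparison of drawn with undrawn configuration (the fact that one of compounds 2 and 3 is drawn with a defined configuration and the other without, at the place where they differ). No direct comparison of R with S has been measured. A change beyond the scatter is therefore not expected in this assay, and the expected step is small (no change at the digits printed from compound 1 to compound 4 (within the scatter)). Compound 4 is expected at (31000 nM), with an estimated range from (13000 nM) to (70000 nM).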

Compound 4, half-maximal cytotoxic concentration: 38000 nM
Compound 4: the middle estimate sits 1.2-fold (0.09 log units) below what was measured; low and high end bracket the measured number.
By their numbers in this assay, from the lowest: compounds 1, 4 and 3 (each within the scatter of the next, the first and the last beyond it). At a limit, above all of these: compound 2.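

Inverting the stereocentre at the saturated chain carbon from R to S gives the first direct comparison of the two configurations, and in this assay the step is a 1.2-fold higher number from compound 1 to compound 4 (0.09 log units; within the scatter). For this pair, then, the configuration at this carbon makes no difference beyond the scatter, and the reading rests on two measured numbers and not on a limit or an undrawn configuration: the fact that compounds 1 and 4 differ only in the configuration as drawn

As far as these compounds go, whether the same holds on the core of compound 3 stays open. So does what an ethyl group in place of the methyl at this stereocentre would do in this assay.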